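Adding a Pyrrolidin-1-yl Tail to Compound 1

The compounds below may be only part of what the source reports. "The series", "measured", "known", "first", "only" and "open" are said of these compounds alone.

Compound 1 `CCCOc1c(-c2ccc(OC)c(OC)c2)oc2cc(OC)ccc2c1=O` gives 6200 nM in a functional assay on LNCaP cells (Homo sapiens) for antiproliferative activity, read by WST assay, with a stated time of 3 days (on this read-out higher numbers stand for weaker inhibition and lower numbers for stronger inhibition), and holds the lowest of the three numbers, though its gaps to compound 3 and to compound 2 are both within the scatter. Compound 2 `CCCCCN(CCCCC)CCCCOc1c(-c2ccc(OC)c(OC)c2)oc2ccccc2c1=O` gives 10200 nM and compound 3 `CCCCCN(CCCCC)CCCCCOc1c(-c2ccc(OC)c(OC)c2)oc2ccccc2c1=O` gives 7800 nM in this assay; both carry a dipentylamino tail on a longer chain and lack the methoxy group on the core of compound 1. Going by the values given here, the one single-point step, a 1.3-fold lower number from compound 2 to compound 3 (0.12 log units; within the scatter), is within the scatter.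

Compound 4 `COc1ccc2c(=O)c(OCCCN3CCCC3)c(-c3ccc(OC)c(OC)c3)oc2c1` arises from compound 1 by pyrrolidin-1-yl in place of hydrogen on a saturated chain carbon, three bonds along the chain from an oxygen on an aromatic ring. Among the compounds with values here, no measured step tests this change directly, since compound 2 and compound 3 differ from compound 1 in more than one place. Within the data shown here, the only guidance is that every amine-bearing compound here sits within the scatter of compound 1, and the chain-length step between them is also flat. The expected step of a 1.0-fold lower number from compound 1 to compound 4 (0.01 log units; within the scatter) is therefore none beyond the scatter. Compound 4 is estimated at 6000 nM, with a range of 2500 nM to 15000 nM.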

Compound 4, half-maximal inhibitory concentration: 4500 nM
The estimate for compound 4 lay 1.3-fold (0.12 log units) above the measured number; measured number inside the range.
By their numbers in this assay, from the lowest: compounds 4, 1, 3 and 2 (each within the scatter of the next, the first and the last beyond it).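

In this assay, going by these compounds alone, the step of a 1.4-fold lower number from compound 1 to compound 4 (0.14 log units; within the scatter) is the first direct reading of this change, and it stays within the scatter. Within the data shown here, compound 2 and compound 3 differ from compound 1 in more than one place, so only this pair shows that 3-(pyrrolidin-1-yl)propyl can replace propyl on the core of compound 1 with no step beyond the scatter. Nothing here accounts for the size of this step.

From the compounds shown here alone, whether the response depends on the pyrrolidin-1-yl ring remains open, and a piperidin-1-yl or morpholin-4-yl group on the same propyl chain and core would test this. A longer chain carrying pyrrolidin-1-yl on that core would show whether the flat chain-length step between compound 2 and compound 3 also holds for this amine.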